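Swapping cyano for chloro on the thiourea aryl group

The compounds below may be only part of what the source reports. "The series", "measured", "known", "first", "only" and "open" are said of these compounds alone.

Values in a functional assay on U-373MG ATCC cells (Homo sapiens) for inhibition, read by MTT assay, with a stated time of 72 h; a lower number here means a stronger inhibitor, a higher number a weaker inhibitor:
compound 1 `CC1(C)CC(NC(=S)Nc2cccc(C#N)c2)c2cc(Br)ccc2O1` gives 6000 nM
compound 2 `CC1(C)CC(NC(=S)Nc2cccc(C#N)c2)c2cc(F)ccc2O1` gives 30000 nM
compound 3 `CC1(C)CC(NC(=O)NCc2ccccc2)c2cc(Cl)ccc2O1` gives 66000 nM

Compound 1 has the lowest of these three numbers, with compound 2 nearest and compound 3 furthest. Compound 4 `CC1(C)CC(NC(=S)Nc2cccc(Cl)c2)c2cc(Br)ccc2O1` differs from compound 1 by chloro in place of cyano on an aromatic carbon in a single swap, chloro in place of cyano on an aromatic carbon, meta to a large group. Within the data shown here, the only measured step, a 5.0-fold higher number from compound 1 to compound 2 (0.70 log units; beyond the scatter) for fluoro in place of bromo, lies at another place and is modest. Among the measured compounds shown here, no measured step covers 3-cyanophenyl to 3-chlorophenyl, so no direction is supported and no step beyond the scatter is expected. The estimated change is a 1.2-fold lower number from compound 1 to compound 4 (0.08 log units; within the scatter) in this assay on this basis. Compound 4 is expected at 5000 nM (estimated range 1800 nM to 15000 nM).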

Compound 4, half-maximal inhibitory concentration: 8000 nM
Beside the measured number, compound 4's estimate is 1.6-fold (0.20 log units) below it; low and high end bracket the measured number.
By their numbers in this assay, from the lowest: compounds 1 and 4 (each within the scatter of the next); then compound 2; then compound 3.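

In this assay, among these compounds, the first measured change on the 3-cyanophenyl group gives a 1.3-fold higher number from compound 1 to compound 4 (0.12 log units; within the scatter) and so, with bromo held on the core, chloro and cyano are not told apart at this place. The only step beyond the scatter among these thioureas remains a 5.0-fold higher number from compound 1 to compound 2 (0.70 log units; beyond the scatter) and lies at the halogen on the core, not on the aryl group. Nothing measured here offers an explanation for this result.

On these data alone, whether an amine, a carboxylic acid or a methoxy group at this place would read differently stays open. Also open, as far as these compounds go, is whether chloro and cyano still read alike with fluoro in place of bromo on the core.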